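The source may hold more compounds than are shown below. What is called first, only, known or untested is meant among the compounds shown, and "the series" means these compounds.

Measured in a functional assay on CWR22R cells (Homo sapiens) for antiproliferative activity, read by CCK-8 assay, with a stated time of 6 days; on this read-out lower numbers stand for stronger inhibition and higher numbers for weaker inhibition:
- Compound 1 `C[C@@H](Cn1ccc(-c2ccc(C#N)c(Cl)c2)n1)NC(=O)c1ccccc1`: "not determined" (no result reported)
- Compound 2 `C[C@@H](Cn1ccc(-c2ccc(C#N)c(Cl)c2)n1)Nc1ccncc1`: 11500 nM
- Compound 3 `C[C@@H](Cn1ccc(-c2ccc(C#N)c(Cl)c2)n1)Nc1cncnc1`: > 30000 nM

Compound 3 gives > 30000 nM in this assay, which is a limit of the assay and not a number. It therefore sits at the limit of > 30000 nM in this assay, at which 1 of the 3 values shown sits, and its true position is not known. Compound 1 has no result, so it offers no guidance.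

The next analogue, compound 4 `C[C@@H](Cn1ccc(-c2ccc(C#N)c(Cl)c2)n1)Nc1ncccn1`, has the same atoms as compound 3, joined differently: pyrimidin-2-yl in place of pyrimidin-5-yl on an amine nitrogen. Thus pyrimidin-2-yl stands in place of pyrimidin-5-yl on an amine nitrogen.

Going by the values given here, only one measured step bears on this change: an at least 2.6-fold higher number from compound 2 to compound 3 (0.41 log units; beyond the scatter). It also exchanges the ring on the amine nitrogen and lies beyond the scatter, towards weaker inhibition. It does not compare two pyrimidine isomers, however, so it gives only weak guidance. Compound 2, at 11500 nM, is the only compound with a measured number, and nothing shown suggests that compound 4 would regain that level. A small change is expected, with compound 4 remaining weak and possibly reaching the limit too. The expected step is an at least 1.2-fold lower number from compound 3 to compound 4 (0.07 log units; that floor lies within the scatter). For compound 4 the estimated value is 25000 nM, with an expected range of 10000 nM to 60000 nM.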

Compound 4, half-maximal inhibitory concentration: 12500 nM
The estimate for compound 4 lay 2.0-fold (0.30 log units) above the measured number; the measured number falls inside the stated range.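

Pyrimidin-2-yl and pyrimidin-5-yl have the same atoms, yet in this assay they do not read alike on the amine nitrogen, and the exchange gives an at least 2.4-fold lower number from compound 3 to compound 4 (0.38 log units; beyond the scatter). Compound 3 gives a limit of the assay and not a number, so the full size of that step stays unknown: the limit of > 30000 nM in this assay, at which 1 of the 4 values shown sits.

The earlier step from pyridin-4-yl to pyrimidin-5-yl could have been read as a penalty for any pyrimidine on this nitrogen, but compound 4 does not fit that reading, with a 1.1-fold higher number from compound 2 to compound 4 (0.04 log units; within the scatter), which lies within the scatter, so pyridin-4-yl and pyrimidin-2-yl cannot be told apart here.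

The compounds shown leave open whether any ring on this nitrogen can do better than the level shared by compound 2 and compound 4, since only these two give numbers. A plain phenyl ring or a pyridin-2-yl ring on the amine nitrogen would test whether the ring nitrogens matter at all, and a methyl group on that same nitrogen would test whether its hydrogen does.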